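The source may report more compounds than this note shows. Statements on the series, on what has been measured and on what is new or still open speak of the compounds shown alone.

The measured compounds and their values:

Compound 1, `O=C(COc1ccc2cc(/C=C3/SC(=O)NC3=O)ccc2c1)Nc1ccccn1`. In an assay on isolated protein for inhibition of histone deacetylase 8 (Homo sapiens), with a stated time of 1 h (on this read-out higher numbers stand for weaker inhibition and lower numbers for stronger inhibition), compound 1 gives > 50000 nM, which is a limit of the assay and not a number.
Compound 2, `O=C(COc1ccc2cc(/C=C3/SC(=O)NC3=O)ccc2c1)Nc1ccccc1`, gives 4500 nM in this assay.
Compound 3, `Cc1cc(Br)ccc1NC(=O)COc1ccc2cc(/C=C3/SC(=O)NC3=O)ccc2c1`, gives 7400 nM in this assay.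

Compound 1 therefore stands only at a limit among the three: it sits at the limit of > 50000 nM in this assay, at which 1 of the 3 values shown sits, so its true value is not known, only its edge. Compound 4, `Cc1cccc2sc(NC(=O)COc3ccc4cc(/C=C5/SC(=O)NC5=O)ccc4c3)nc12`, differs from compound 1 in one place:

4-methyl-1,3-benzothiazol-2-yl in place of pyridin-2-yl on an amide-type nitrogen

Two measured steps start from compound 1 and bear on this change. Replacing the pyridin-2-yl on the amide-type nitrogen with a carbon-only aromatic ring gave an at least 11-fold lower number from compound 1 to compound 2 (1.04 log units; beyond the scatter) and an at least 6.7-fold lower number from compound 1 to compound 3 (0.82 log units; beyond the scatter). Between the two aryl variants themselves the difference was a 1.6-fold higher number from compound 2 to compound 3 (0.22 log units; within the scatter). Both steps away from the pyridin-2-yl thus lower the number in this assay by a large margin, while the choice between the two aryl groups matters little. Compound 4 carries a fused bicyclic heteroaryl rather than a single carbon-only ring, so the step is expected to be of similar direction and size: an at least 8.3-fold lower number from compound 1 to compound 4 (0.92 log units; beyond the scatter). Compound 4 is expected to give about 6000 nM, within a range from 2000 nM to 25000 nM.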

Compound 4, half-maximal inhibitory concentration: 5800 nM
The estimate for compound 4 lay 1.0-fold (0.01 log units) above the measured number; measured number inside the range.
By their numbers in this assay, from the lowest: compounds 2, 4 and 3 (each within the scatter of the next). At a limit, above all of these: compound 1.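

In this assay, the move away from pyridin-2-yl now holds for a third group, the fused 4-methyl-1,3-benzothiazol-2-yl, which gives an at least 8.6-fold lower number from compound 1 to compound 4 (0.93 log units; beyond the scatter). Set against the two carbon-only rings, the same group gives a 1.3-fold lower number from compound 3 to compound 4 (0.11 log units; within the scatter) and a 1.3-fold higher number from compound 2 to compound 4 (0.11 log units; within the scatter), so phenyl, 4-bromo-2-methylphenyl and 4-methyl-1,3-benzothiazol-2-yl on the amide-type nitrogen cannot be told apart here, and a nitrogen in the aromatic ring is not in itself enough to put a compound where compound 1 stands. Compound 1 remains a limit and not a number, so each step from it marks only an edge: the limit of > 50000 nM in this assay, at which 1 of the 4 values shown sits.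

The compounds shown leave open whether pyridin-3-yl or pyridin-4-yl on the same nitrogen would stand with compound 1 or with the other three. Also open, as far as these compounds go, is whether an unsubstituted 1,3-benzothiazol-2-yl or a single thiazol-2-yl ring would match compound 4, and what an amine or a carboxylic acid on the phenyl ring would do to the number.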